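Acetamido on the aryl ether of compound 1

A few compounds are considered here, and "the series" means these few. Any claim that something is new, unique, unknown or untested is made for them only; others in the source may bear on it.

Compound 1 `Cc1cc(COc2ccccc2)nc(-c2ccccn2)n1` gives 794 nM in a functional assay on cells for antagonist activity at Free fatty acid receptor 1 (Homo sapiens), read by TR-FRET and inositol phosphate accumulation, with a stated time of 2 h (on this read-out lower numbers stand for stronger inhibition and higher numbers for weaker inhibition), the second highest of the three values recorded. Compound 2 `Cc1cc(COc2ccc(Cl)cc2)nc(-c2ccccn2)n1` gives 251 nM and compound 3 `COc1ccc(OCc2cc(C)nc(-c3ccccn3)n2)cc1` gives 7940 nM. The step of a 3.2-fold lower number from compound 1 to compound 2 (0.50 log units; beyond the scatter) is modest and downward, a 10-fold higher number from compound 1 to compound 3 (1.00 log units; beyond the scatter) is upward, and a 32-fold higher number from compound 2 to compound 3 (1.50 log units; beyond the scatter) is large. Compound 4 `CC(=O)Nc1ccccc1OCc1cc(C)nc(-c2ccccn2)n1` differs from compound 1 by acetamido in place of hydrogen on an aromatic carbon. Both measured steps from compound 1 also exchange hydrogen for a substituent on that aromatic ring, so they bear on this change, though the new group sits ortho to a large group and the earlier positions are not stated here. The closer analogy is the methoxy of compound 3 rather than the chloro of compound 2, so an upward step is expected, estimated as a 3.8-fold higher number from compound 1 to compound 4 (0.58 log units; beyond the scatter). Compound 4 is therefore expected at 3000 nM, within 800 nM to 12000 nM.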

Compound 4, half-maximal inhibitory concentration: > 39800 nM
Compound 4: only a limit was reported; the forecaster's own chance of this, stated with the estimate: 10%; at least 13-fold (1.12 log units) between middle value and limit.
By their numbers in this assay, from the lowest: compound 2; then compound 1; then compound 3. At a limit, above all of these: compound 4.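

In this assay compound 4 reads > 39800 nM, which is a limit and not a number. Acetamido ortho to a large group brings an at least 50-fold higher number from compound 1 to compound 4 (1.70 log units; beyond the scatter), the largest upward step shown from this parent. Hydrogen replacement on this ring can therefore cost more than the methoxy of compound 3 showed at 7940 nM.

The compounds shown do not separate the effect of this position from that of acetamido itself. An amine or a methyl on the same carbon would bear on that question.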